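Carbamate to pivalamide on the shared core

This account rests on a few compounds, and the source may have more. Where it says the series, first, only, none or still open, it means among the compounds named here.

Two compounds of the series carry a measurement. Within the data shown here, compound 1 `COc1ccc([N+](=O)[O-])cc1CSc1nc2cc(NC(=O)NC(C)(C)C)ccc2n1Cc1ccccc1` and compound 2 `COc1ccc([N+](=O)[O-])cc1CSc1nc2cc(NC(=O)OC(C)(C)C)ccc2n1C(C)C` differ from each other in more than one place, so no single step joins them; their numbers can only be set side by side. In an assay on isolated protein for inhibition of Gonadotropin-releasing hormone receptor (Rattus norvegicus) (a lower number here means a stronger inhibitor, a higher number a weaker inhibitor), compound 2 gives 710 nM, the higher of the two numbers in hand. In the same assay compound 1 gives 160 nM, and the gap between the two lies beyond the usual scatter.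

Compound 3 `COc1ccc([N+](=O)[O-])cc1CSc1nc2cc(NC(=O)C(C)(C)C)ccc2n1C(C)C` has not been measured. It differs from compound 2 by tert-butyl in place of tert-butoxy on a carbonyl carbon. Among the measured compounds shown here, no measured pair shows this change, and the two numbers in hand give no step against which to set it. The step expected from compound 2 to compound 3 is a 1.3-fold lower number from compound 2 to compound 3 (0.11 log units; within the scatter), and it is not expected to reach beyond the scatter in either direction. For compound 3 the value expected in this assay is 550 nM, with a range from 150 nM to 2000 nM.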

Compound 3, half-maximal inhibitory concentration: > 10000 nM
Compound 3 gave a limit, no number; the forecaster's own chance of this, stated with the estimate: 5%; middle value at least 18-fold (1.25 log units) from the limit.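

Among these compounds, the single change at this place, on a carbonyl carbon whose other neighbour is an amide-type nitrogen, is the first step that can be read, and in this assay it is large: an at least 14-fold higher number from compound 2 to compound 3 (1.14 log units; beyond the scatter). Among the compounds shown here, compound 3 gives a limit and not a number, so this step has a floor but no fixed size: the limit of > 10000 nM in this assay, at which 1 of the 3 values shown sits. The earlier compounds could not show that this place tolerates so little, since tert-butoxy and tert-butyl share the same tert-butyl carbons and the (tert-butoxycarbonyl)amino group of compound 2 keeps a measurable value while the ((tert-butyl)carbonyl)amino group of compound 3 does not.

The compounds shown do not tell whether the loss follows the oxygen itself or the tert-butyl group's new attachment, and compound 1 differs from compound 3 in more than one place, so its urea cannot settle this. Also open, as far as these compounds go, is what a smaller group on the same carbonyl carbon, such as methoxy, or a longer chain such as n-butoxy, would give in this assay.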